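This account rests on a few compounds, and the source may have more. Where it says the series, first, only, none or still open, it means among the compounds named here.

Measured so far in a functional assay on A549 cells (Homo sapiens) for cytotoxicity, with a stated time of 48 h; on this read-out lower numbers stand for stronger inhibition and higher numbers for weaker inhibition:
- compound 1 `CC(C)COc1ccc2oc(/C=C/[S+](C)[O-])cc(=O)c2c1`: 1100 nM
- compound 2 `C[S+]([O-])/C=C/c1cc(=O)c2ccccc2o1`: 1900 nM
- compound 3 `C[S+]([O-])/C=C/c1cc(=O)c2cc(O)ccc2o1`: 10500 nM

Compound 2 stands second highest of the three numbers. Toward compound 1 the step is a 1.7-fold higher number from compound 1 to compound 2 (0.24 log units; within the scatter), within the scatter; toward compound 3 it is a 5.5-fold higher number from compound 2 to compound 3 (0.74 log units; beyond the scatter), beyond it.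

Compound 4 `COc1cccc2oc(/C=C/[S+](C)[O-])cc(=O)c12` differs from compound 2 by methoxy in place of hydrogen on an aromatic carbon, the new group sitting ortho to a fused ring. Within the data shown here, two measured steps bear on it loosely: adding an oxygen substituent on the aromatic ring, a 5.5-fold higher number from compound 2 to compound 3 (0.74 log units; beyond the scatter), raised the number; removing isobutoxy, a 1.7-fold higher number from compound 1 to compound 2 (0.24 log units; within the scatter), stayed within the scatter. Neither places a methoxy where compound 4 carries it. The expected step is therefore small, a 1.3-fold higher number from compound 2 to compound 4 (0.10 log units; within the scatter), a slight rise at most. Compound 4 is estimated at 2400 nM, with a range of 900 nM to 6500 nM.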

Compound 4, half-maximal inhibitory concentration: 3800 nM
Compound 4: middle estimate off by 1.6-fold (0.20 log units), on the low side; the range from low to high includes it.
By their numbers in this assay, from the lowest: compounds 1, 2 and 4 (each within the scatter of the next, the first and the last beyond it); then compound 3.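

Methoxy on this aromatic carbon, ortho to a fused ring, gives a 2.0-fold higher number from compound 2 to compound 4 (0.30 log units; within the scatter) in this assay, so no change can be read at this position. The hydroxy step a 5.5-fold higher number from compound 2 to compound 3 (0.74 log units; beyond the scatter) involves a different group on a different aromatic carbon, so it says nothing direct about this position. Nothing available explains the result.

Open, going by these compounds, is whether an amine or a longer chain such as isobutoxy on this same carbon would stay within the scatter of compound 2. A hydroxy group here is equally unresolved.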